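Benzoyl for Hydrogen on the Oxygen of Compound 2

The compounds below may be only part of what the source reports. "The series", "measured", "known", "first", "only" and "open" are said of these compounds alone.

Going by the values given here, in a functional assay on B16 cells (Mus musculus) for antiproliferative activity, with a stated time of 72 h (on this read-out lower numbers stand for stronger inhibition and higher numbers for weaker inhibition), compound 2 `CSc1cnc2ccccc2c1SCC#CCO` gives 49.8 ug/mL, the highest of the two numbers so far; its nearest neighbour, compound 1 `CCOC(=O)OCC#CCSc1c(SC)cnc2ccccc12`, gives 5.5 ug/mL. Among the compounds with values here, the one measured step, a 9.1-fold higher number from compound 1 to compound 2 (0.96 log units; beyond the scatter), came from hydrogen in place of ethoxycarbonyl on an oxygen on a saturated carbon. Compound 3 `CSc1cnc2ccccc2c1SCC#CCOC(=O)c1ccccc1` carries benzoyl in place of hydrogen on an oxygen on a saturated carbon, an acyl group returning to the same oxygen. A lower number of about the same size is expected, an 8.3-fold lower number from compound 2 to compound 3 (0.92 log units; beyond the scatter), because a 9.1-fold higher number from compound 1 to compound 2 (0.96 log units; beyond the scatter) lay beyond the scatter. Compound 3 is estimated at 6 ug/mL, with a range of 2 ug/mL to 20 ug/mL.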

Compound 3, concentration for 50% inhibition: 17.8 ug/mL
Estimate against measurement, compound 3: 3.0-fold (0.47 log units) below; low and high end bracket the measured number.
By their numbers in this assay, from the lowest: compound 1; then compound 3; then compound 2.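

In this assay, benzoyl on the oxygen on a saturated carbon also lowers the number (a 2.8-fold lower number from compound 2 to compound 3 (0.45 log units; beyond the scatter)), so a second acyl group at this position moves the read-out in the same direction as ethoxycarbonyl. The two acyl groups do not match, however: phenyl in place of ethoxy on a carbonyl carbon gives a separate step (a 3.2-fold higher number from compound 1 to compound 3 (0.51 log units; beyond the scatter)), so the outcome depends on what the carbonyl carries. Nothing available accounts for this difference. Open, from the compounds shown here alone, is how a methyl ether or an acetyl group on this oxygen would compare, and whether an amine in place of the oxygen would keep the lower numbers.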